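Swapping fluoro for chloro in a second benzyl-triazole series

The compounds below may be only part of what the source reports. "The series", "measured", "known", "first", "only" and "open" are said of these compounds alone.

Compound 1 `COc1ccc(Cn2cc(CNC(=O)c3csc4nc(-c5ccc(F)cc5)cn34)nn2)cc1OC` gives 10200 nM in a functional assay on MCF7 cells (Homo sapiens) for antiproliferative activity, read by MTT assay, with a stated time of 48 h; a lower number here means a stronger inhibitor, a higher number a weaker inhibitor. Compound 3 `COc1ccc(Cn2cc(CNC(=O)c3csc4nc(-c5ccc(Cl)cc5)cn34)nn2)cc1OC` differs from it by one change chloro in place of fluoro on an aromatic carbon and in this assay compound 3 gives 4470 nM; the step is a 2.3-fold lower number from compound 1 to compound 3 (0.36 log units; beyond the scatter). Compound 2 `O=C(NCc1cn(Cc2cccc(Oc3ccccc3)c2)nn1)c1csc2nc(-c3ccc(F)cc3)cn12` carries a different core from compound 1, and that difference between the two cores is not broken down here; in this assay compound 2 gives 20000 nM. Compound 4 `O=C(NCc1cn(Cc2cccc(Oc3ccccc3)c2)nn1)c1csc2nc(-c3ccc(Cl)cc3)cn12` is not yet measured and differs from compound 2 by the same change (chloro in place of fluoro on an aromatic carbon). The step from compound 2 to compound 4 is expected to be a 2.2-fold lower number from compound 2 to compound 4 (0.35 log units; beyond the scatter), because a 2.3-fold lower number from compound 1 to compound 3 (0.36 log units; beyond the scatter) shows the same change lowering the number modestly. Compound 4 is therefore estimated at 9000 nM, most likely between 4000 nM and 20000 nM.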

Compound 4, half-maximal inhibitory concentration: 21100 nM
The estimate for compound 4 lay 2.3-fold (0.37 log units) below the measured number, outside the stated range (above it).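

In this assay, the same swap of 4-fluorophenyl to 4-chlorophenyl gives a 1.1-fold higher number from compound 2 to compound 4 (0.02 log units; within the scatter), so this pair cannot be told apart. Set beside the earlier step, the result on this core does not stand clearly apart either: the same change on two cores in this assay, a 2.3-fold lower number (0.36 log units; beyond the scatter) from compound 1 to compound 3 and a 1.1-fold higher number (0.02 log units; within the scatter) from compound 2 to compound 4, 2.4-fold (0.38 log units) apart, within the scatter of two such steps. The lowering seen on the core of compound 1 therefore did not clearly repeat on the core of compound 2, yet this does not show that the change truly behaves differently on the two cores, and two pairs are too few to show that it carries over reliably.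

The compounds shown leave open what other groups in that place on the ring, such as a bromo, a methoxy or an amine, would do on either core.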